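The compounds below may be only part of what the source reports. "The series", "measured", "known", "first", "only" and "open" are said of these compounds alone.

Measured so far:
compound 1 `O/N=C(/Nc1cccc(Cl)c1)c1ccc2occc2c1` — 690 nM
compound 2 `O/N=C(/Nc1cccc(F)c1)c1ccc2oc(-c3ccccc3)cc2c1` — 11000 nM

In an assay on isolated protein for inhibition of Indoleamine 2,3-dioxygenase 1 (Homo sapiens), read by spectrophotometry (a higher number here means a weaker inhibitor, a lower number a stronger inhibitor), compound 2 gives 11000 nM, the higher of the two numbers shown, while compound 1 gives 690 nM; the two differ in more than one place, so their values can only be set side by side. Compound 3 `O/N=C(/Nc1cccc(Cl)c1)c1ccc2oc(-c3ccccc3)cc2c1` differs from compound 2 by chloro in place of fluoro on an aromatic carbon. For the measured compounds named here, no measured pair shows this single change, so its size is unknown; a small step toward a lower number, or none beyond the scatter, is expected, as a 1.8-fold lower number from compound 2 to compound 3 (0.26 log units; within the scatter). Compound 3 is estimated at 6000 nM, with a range from 2500 nM to 15000 nM.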

Compound 3, half-maximal inhibitory concentration: 900 nM
Beside the measured number, compound 3's estimate is 6.7-fold (0.82 log units) above it, outside the stated range (below it).
By their numbers in this assay, from the lowest: compounds 1 and 3 (each within the scatter of the next); then compound 2.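

In this assay, chloro in place of fluoro on an aromatic carbon is a large step (a 12-fold lower number from compound 2 to compound 3 (1.09 log units; beyond the scatter)), so with phenyl on the core this position is sensitive to the change from 3-fluorophenyl to 3-chlorophenyl. With chloro present, phenyl in place of hydrogen on an aromatic carbon stays within the scatter (a 1.3-fold higher number from compound 1 to compound 3 (0.12 log units; within the scatter)). Nothing given here accounts for the size of the chloro step. As far as these compounds go, whether that step would be as large without the phenyl remains open, as does how a bromo or methoxy group would read at this position.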